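Dimethylamino in place of amino on an inactive compound

The compounds below may be only part of what the source reports. "The series", "measured", "known", "first", "only" and "open" are said of these compounds alone.

In a functional assay on ML1 cells (Homo sapiens) for antiproliferative activity, read by WST assay, with a stated time of 3 days (on this read-out lower numbers stand for stronger inhibition and higher numbers for weaker inhibition), compound 1 `O=c1cc(I)n([C@@H]2O[C@H](CO)[C@@H](O)[C@H]2O)c(=O)[nH]1` gives 15300 nM as a measured number. Compound 2 `[N-]=[N+]=Nc1cc(=O)[nH]c(=O)n1[C@@H]1O[C@H](CO)[C@@H](O)[C@H]1O` gives only a limit of the assay (> 50000 nM). Compound 3 `Nc1cc(=O)[nH]c(=O)n1[C@@H]1O[C@H](CO)[C@@H](O)[C@H]1O` also gives only a limit (> 50000 nM) and so has no number of its own. Compound 4 `CN(C)c1cc(=O)[nH]c(=O)n1[C@@H]1O[C@H](CO)[C@@H](O)[C@H]1O` carries dimethylamino in place of amino on an aromatic carbon. Two steps away from iodo bear on this (an at least 3.2-fold higher number from compound 1 to compound 2 (0.51 log units; beyond the scatter)) and (an at least 3.2-fold higher number from compound 1 to compound 3 (0.51 log units; beyond the scatter)), and both are at least modest. The closest step (a step that the two limits leave unreadable from compound 2 to compound 3) cannot be sized. No step beyond the scatter is therefore expected in this assay in either direction. The estimated step is (a step that the limit leaves unreadable from compound 3 to compound 4). Compound 4 is expected near 60000 nM within a range from 25000 nM to 150000 nM and will probably return only a limit again.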

Compound 4, half-maximal inhibitory concentration: > 50000 nM
Compound 4 was reported as a limit (the forecaster's own chance of this, stated with the estimate: 75%); the middle value does not contradict the limit.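

Replacing iodo with dimethylamino in this assay gives an at least 3.2-fold higher number from compound 1 to compound 4 (0.51 log units; beyond the scatter) and so adds a third group at this place that returns no measured number. Here, the change from amino to dimethylamino adds two carbons and removes a hydrogen-bond donor, yet the result stays a limit. The steps among compound 2, compound 3 and compound 4 cannot be read, because all three stand at the same limit: the limit of > 50000 nM in this assay, at which 3 of the 4 values shown sit.

As far as these compounds go, whether activity at this place is particular to iodo stays open. A bromo, chloro or methyl group there could show whether another group also gives a measured number.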